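This account rests on a few compounds, and the source may have more. Where it says the series, first, only, none or still open, it means among the compounds named here.

Of the compounds shown here, three have been measured so far. Compound 1 `COc1cc(OC)c(-c2cc(=O)c3cc(O)ccc3o2)cc1OC` gives 2.14 ug/mL in a functional assay, read by Griess assay, with a stated time of 2.5 h; on this read-out lower numbers stand for stronger inhibition and higher numbers for weaker inhibition. Compound 3 `COc1cc(OC)c(-c2cc(=O)c3cc(Cl)ccc3o2)cc1OC` differs from compound 1 in one place. In this assay compound 3 gives 2.15 ug/mL, and the step of a 1.0-fold higher number from compound 1 to compound 3 (0.00 log units; within the scatter) is therefore flat. Compound 2 `COc1cc(OC)c(OC)cc1/C=C/C(=O)c1ccc(O)cc1O`, built on a different core, gives 2.76 ug/mL in this assay; this is the highest of the three numbers, but its gaps to compound 3 and to compound 1 both lie within the scatter, so no order among the three can be claimed.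

The next compound, compound 4 `COc1cc(OC)c(OC)cc1/C=C/C(=O)c1ccccc1`, differs from compound 2 in one place: phenyl in place of 2,4-dihydroxyphenyl on a carbonyl carbon. Among the measured compounds shown here, no measured step makes this exchange on the core of compound 2. For the measured compounds named here, the only step that bears on it at all is the one between compound 1 and compound 3 a 1.0-fold higher number from compound 1 to compound 3 (0.00 log units; within the scatter), where a hydroxy on an aromatic carbon was exchanged on another core without any shift beyond the scatter. On that basis only a small step is expected, if any, leaning toward a higher number, with an expected step of a 1.3-fold higher number from compound 2 to compound 4 (0.10 log units; within the scatter). Compound 4 is therefore estimated at 3.5 ug/mL in this assay, with a range from 1.5 ug/mL to 9 ug/mL.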

Compound 4, half-maximal inhibitory concentration: 2.01 ug/mL
Estimate against measurement, compound 4: 1.7-fold (0.24 log units) above; low and high end bracket the measured number.
By their numbers in this assay, from the lowest: compounds 4, 1, 3 and 2 (each within the scatter of the next).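

Among the compounds shown here, on the core of compound 2, putting phenyl in place of 2,4-dihydroxyphenyl on the carbonyl carbon gives a 1.4-fold lower number from compound 2 to compound 4 (0.14 log units; within the scatter) in this assay, so this position now has a direct reading of its own, where the earlier compounds offered only a hydroxy exchange on another core. The hydrogen-bond donors and acceptors counted on the 2,4-dihydroxyphenyl group are all absent from phenyl, yet the step stays within the scatter, so on this core neither hydroxy is required for a number in this range in this assay. No independent measurement is available that could explain this result.

The compounds shown leave open whether one hydroxy alone on the phenyl ring would read like the pair or like the bare ring, since both were exchanged together in this step. They also leave open whether an amine or a carboxylic acid on that ring would shift the number beyond the scatter, as no step shown at this position or on the other core does so.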